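The source may hold more compounds than are shown below. What is called first, only, known or untested is meant among the compounds shown, and "the series" means these compounds.

Compound 1 `COc1c(Cl)ccc2c1CCC2c1ncc[nH]1` opens the small set. In a functional assay on CHO cells for agonist activity at Alpha-1B adrenergic receptor (Homo sapiens), read by FLIPR and calcium flux (on this read-out lower numbers stand for an effect already at smaller amounts and higher numbers for an effect only at larger amounts of compound), compound 1 gives > 10000 nM, which is a limit of the assay and not a number. Compound 2 `Cn1cc(-c2cccc3c2CCC3c2ncc[nH]2)cn1` is the second measured member. In this assay compound 2 gives > 10000 nM, again a limit of the assay rather than a number. Compound 2 therefore stands where every value shown stands, at the limit of > 10000 nM in this assay, at which 2 of the 2 values shown sit, so no order between the two measured compounds can be read from these values. Compound 3 `Cn1ccc(-c2cccc3c2CCC3c2ncc[nH]2)n1` has not yet been measured; it differs from compound 2 by 1-methyl-1H-pyrazol-3-yl in place of 1-methyl-1H-pyrazol-4-yl on an aromatic carbon. For the measured compounds named here, no measured step between two compounds that differ in one place is at hand, and both values shown sit at the limit. The step expected here is a step that the limit leaves unreadable from compound 2 to compound 3, nothing beyond the scatter, with the limit again the most likely outcome. The estimate for compound 3 is 15000 nM, within a range from 5000 nM to 50000 nM.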

Compound 3, half-maximal effective concentration: > 10000 nM
Compound 3 ended at the assay's limit; the forecaster's own chance of this, stated with the estimate: 85%; the middle value is on the limit's open side.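

For the compounds shown here, compound 3 joins compound 2 at the limit, so no step between compound 2 and compound 3 can be read: the limit of > 10000 nM in this assay, at which 3 of the 3 values shown sit. The compounds shown leave open whether compound 2 and compound 3 differ at all in this assay and how compound 1, compound 2 and compound 3 would rank.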